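The compounds below may be only part of what the source reports. "The series", "measured", "known", "first", "only" and "open" are said of these compounds alone.

Series notes. Compound 1 `O=[N+]([O-])c1cccc(NS(=O)(=O)c2ccc(F)cc2)c1` and compound 2 `O=[N+]([O-])c1cccc(NS(=O)(=O)c2ccc(Cl)cc2)c1` share one core. In an ADME assay, compound 1 gives 7.85 and compound 2 gives 7.51. The change between them is fluoro in place of chloro on an aromatic carbon and the step is a number 0.34 log units higher from compound 2 to compound 1 (beyond the scatter). Compound 3 `O=S(=O)(Nc1ccc(Cl)cc1)c1ccccc1` has a different core; the difference between the two cores is not broken down here. In this assay compound 3 gives 8.75, the highest of the three numbers. Compound 4 `O=S(=O)(Nc1ccc(F)cc1)c1ccccc1` is not yet measured; it differs from compound 3 by fluoro in place of chloro on an aromatic carbon, the same change as between compound 2 and compound 1. For compound 4 the expected step in this assay is a number 0.34 log units higher from compound 3 to compound 4 (beyond the scatter), about the size of the earlier one, because compound 3 gives 8.75 and the earlier step was a number 0.34 log units higher from compound 2 to compound 1 (beyond the scatter). Compound 4 is thus expected to give 9.09 in this assay, likely between 8.75 and 9.45.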

Compound 4, acid dissociation constant: 8.85
Compound 4: middle estimate off by 0.24 log units, on the high side; the measured number falls inside the stated range.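

In this assay, fluoro in place of chloro on an aromatic carbon gives a number 0.10 log units higher from compound 3 to compound 4 (within the scatter), and the step does not differ measurably from the one seen on the other core: the same change on two cores in this assay, a number 0.34 log units higher (beyond the scatter) from compound 2 to compound 1 and a number 0.10 log units higher (within the scatter) from compound 3 to compound 4, 0.24 log units apart, within the scatter of two such steps. Carrying the change from one core to the other is therefore compatible with these numbers, although only the earlier step lies beyond the scatter. Two pairs do not establish a common step size, nor do they show that the change would behave alike on a further core.

The compounds shown hold only fluoro and chloro at the changed place, so the effect of a methoxy group, an amine or a carboxylic acid there stays open. On these data alone, the separate contribution of each difference between the two cores also stays open.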